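This account rests on a few compounds, and the source may have more. Where it says the series, first, only, none or still open, it means among the compounds named here.

Measured compounds:
compound 1, `Cc1nn(-c2ccccn2)c2cc(-c3ccc(CC(C)(C)C(=O)O)cc3)ccc12`, in a functional assay on cells for agonist activity at Free fatty acid receptor 1 (Mus musculus), read by FLIPR and calcium flux, with a stated time of 5 min (a higher number here means that more compound is needed for the effect, a lower number that less compound is needed), gives > 100000 nM
compound 2, `Cc1nn(-c2ccccn2)c2cc(-c3ccc(CCC(=O)O)cc3)ncc12`, in this assay gives 9200 nM

The value of compound 1 is a limit of the assay, not a number (the limit of > 100000 nM in this assay, at which 1 of the 2 values shown sits). Compound 2 therefore stands as the only number shown in this assay. Compound 3, `Cc1nn(-c2ccccn2)c2cc(-c3ccc(C(C)CC(=O)O)cc3)ncc12`, differs from compound 2 by methyl in place of hydrogen on a saturated chain carbon bound to an aromatic carbon and a saturated chain carbon. For the measured compounds named here, no measured step covers a change of this kind, so no direction is supported; a step within the scatter is expected. Compound 3 is estimated at 7000 nM, range 1800 nM to 28000 nM, a step of a 1.3-fold lower number from compound 2 to compound 3 (0.12 log units; within the scatter) from compound 2.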

Compound 3, half-maximal effective concentration: 61000 nM
Estimate against measurement, compound 3: 8.7-fold (0.94 log units) below, and the stated range ends below it.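

In this assay, methyl in place of hydrogen on a saturated chain carbon bound to an aromatic carbon and a saturated chain carbon gives a 6.6-fold higher number from compound 2 to compound 3 (0.82 log units; beyond the scatter). For the compounds shown here, this is the first step measured, and it shows that this chain carbon does not accept the change from 2-carboxyethyl to 1-(carboxymethyl)ethyl without a loss beyond the scatter. Nothing measured here gives a reason for this step.

From the compounds shown here alone, it remains open whether fluorine or a hydroxyl group on the same carbon would give a similar step. A longer chain ending in the carboxylic acid is also untested in these data.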